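The source may report more compounds than this note shows. Statements on the series, on what has been measured and on what is new or still open speak of the compounds shown alone.

Compound 1 `O=C(N/N=C/c1ccc([N+](=O)[O-])cc1)Nc1ccc(Oc2ccnc3[nH]ccc23)c(F)c1`: 4000 nM
Compound 2 `CN(C)CCn1cccc1/C=N/NC(=O)Nc1ccc(Oc2ccnc3[nH]ccc23)c(F)c1`: "not determined" (no result reported)

Within the data shown here, in a functional assay on MCF7 cells (Homo sapiens) for antiproliferative activity, read by MTT assay, with a stated time of 72 h (on this read-out lower numbers stand for stronger inhibition and higher numbers for weaker inhibition), compound 1 gives 4000 nM, the only number available. Compound 2 stands at "not determined" (no result reported), so it has no place on the scale. Compound 3 `O=C(N/N=C/c1cccn1CCCN1CCCCC1)Nc1ccc(Oc2ccnc3[nH]ccc23)c(F)c1` keeps the shared core and alters only the side chain. The change reads ((piperidin-1-yl)methyl in place of dimethylamino on a saturated chain carbon, two bonds along the chain from an aromatic nitrogen), that is, (piperidin-1-yl)methyl in place of dimethylamino on a saturated chain carbon, two bonds along the chain from an aromatic nitrogen. With no measured baseline for this change, no step beyond the scatter is expected in this assay, in either direction. Compound 3 is estimated at 2500 nM, with an expected range of 500 nM to 10000 nM.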

Compound 3, half-maximal inhibitory concentration: 4840 nM
Compound 3: middle estimate off by 1.9-fold (0.29 log units), on the low side, and the stated range covers the measured number.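

In this assay, among these compounds, compound 2 stands at "not determined" (no result reported) and compound 3 at 4840 nM so no step between them can be read. Going by these compounds, what 3-(piperidin-1-yl)propyl in place of 2-(dimethylamino)ethyl does to this read-out stays open, and no evidence bears on it.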